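Removing the methoxy from the benzoyl of compound 2

A few compounds are considered here, and "the series" means these few. Any claim that something is new, unique, unknown or untested is made for them only; others in the source may bear on it.

Two members of the series carry numbers in a functional assay on G55T2 cells (Homo sapiens) for antiproliferative activity, read by WST assay, with a stated time of 72 h; on this read-out lower numbers stand for stronger inhibition and higher numbers for weaker inhibition. Compound 1 `Cc1ccc(NC(=O)CCN(Cc2ccc(C(=O)NO)cc2)C(=O)c2cc(C)cc(C)c2)cc1` gives 370 nM, and compound 2 `COc1ccc(C(=O)N(CCC(=O)NCc2ccccc2)Cc2ccc(C(=O)NO)cc2)cc1` gives 3490 nM, the higher of the two, with the gap to compound 1 beyond the scatter. Compound 3 `O=C(CCN(Cc1ccc(C(=O)NO)cc1)C(=O)c1ccccc1)NCc1ccccc1` is the unmeasured partner of compound 2; the difference is hydrogen in place of methoxy on an aromatic carbon, read one bond further out as 4-methoxyphenyl to phenyl. Within the data shown here, no measured pair shows this change, so its direction is unknown. A step of no size beyond the scatter is expected, the estimated change being a 1.2-fold lower number from compound 2 to compound 3 (0.07 log units; within the scatter). For compound 3 the estimate is 3000 nM, within 1200 nM to 8000 nM.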

Compound 3, half-maximal inhibitory concentration: 5940 nM
Estimate against measurement, compound 3: 2.0-fold (0.30 log units) below, within the range that was stated.
By their numbers in this assay, from the lowest: compound 1; then compounds 2 and 3 (each within the scatter of the next).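

In this assay, the exchange of methoxy for hydrogen on this aromatic carbon, para to a large group, gives a 1.7-fold higher number from compound 2 to compound 3 (0.23 log units; within the scatter), so this pair does not separate the two groups at this position. Among these compounds, this is the first direct reading of the change, and it holds for this one pair only. Nothing at hand bears on the reason for this result.

Open, on these data alone, is whether an amine, a carboxylic acid or a longer alkoxy chain on this carbon would give a step beyond the scatter. Also open, as far as these compounds go, is whether the same exchange reads alike on other members.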